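Swapping pyridin-4-yl for 3-carbamoylphenyl

The source may hold more compounds than are shown below. What is called first, only, known or untested is meant among the compounds shown, and "the series" means these compounds.

Measured in a functional assay on HL-60 cells (Homo sapiens) for cytotoxicity, read by CellTiter-Blue, with a stated time of 48 h; on this read-out higher numbers stand for weaker inhibition and lower numbers for stronger inhibition:
- Compound 1 `CCOC(=O)CC1C(C(=O)OCC)=C(N)Oc2ccc(-c3ccc(F)cc3F)cc21`: 76600 nM
- Compound 2 `CCOC(=O)CC1C(C(=O)OCC)=C(N)Oc2ccc(-c3cccs3)cc21`: > 80000 nM (a limit, not a number)
- Compound 3 `CCOC(=O)CC1C(C(=O)OCC)=C(N)Oc2ccc(-c3ccncc3)cc21`: 10200 nM

Compound 3 has the lowest number of the set, and so the strongest inhibition. Compound 4 `CCOC(=O)CC1C(C(=O)OCC)=C(N)Oc2ccc(-c3cccc(C(N)=O)c3)cc21` differs from it in one group: 3-carbamoylphenyl in place of pyridin-4-yl on an aromatic carbon. Two measured swaps at this carbon bear on the change: a 7.5-fold lower number from compound 1 to compound 3 (0.88 log units; beyond the scatter) and an at least 7.8-fold lower number from compound 2 to compound 3 (0.89 log units; beyond the scatter). Compound 4 gives up pyridin-4-yl for a ring of carbon only, and compound 1, also carrying such a ring, gives 76600 nM. A move towards a higher number is therefore expected, probably smaller than those swaps. The estimated step is a 2.7-fold higher number from compound 3 to compound 4 (0.44 log units; beyond the scatter). For compound 4 the estimated value is 28000 nM, with an expected range of 8000 nM to 80000 nM.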

Compound 4, half-maximal inhibitory concentration: 5400 nM
Estimate against measurement, compound 4: 5.2-fold (0.71 log units) above, outside the stated range (below it).
By their numbers in this assay, from the lowest: compounds 4 and 3 (each within the scatter of the next); then compound 1. At a limit, above all of these: compound 2.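

In this assay, pyridin-4-yl is not needed at this aromatic carbon: with a ring of carbon only, the result is a 1.9-fold lower number from compound 3 to compound 4 (0.28 log units; within the scatter), so compounds 3 and 4 cannot be told apart. A ring of carbon only does not settle the outcome either, as the change from 2,4-difluorophenyl to 3-carbamoylphenyl gives a 14-fold lower number from compound 1 to compound 4 (1.15 log units; beyond the scatter). Compound 2 has a limit, not a number, so an at least 14-fold lower number from compound 2 to compound 4 (1.17 log units; beyond the scatter) is only a floor: the limit of > 80000 nM in this assay, at which 1 of the 4 values shown sits.

As far as these compounds go, what remains open is whether the carbamoyl group itself accounts for the gain over compound 1. A carboxylic acid or an amine in its place on the phenyl ring would test this.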